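Thiazole substituent exchange on the phenol-linked series

The compounds below may be only part of what the source reports. "The series", "measured", "known", "first", "only" and "open" are said of these compounds alone.

Measured so far:
compound 1 `CN(C)c1noc(-c2cccc(CNc3ccc4[nH]nc(C(=O)O)c4c3)c2Cl)n1` — 180 nM in an assay on isolated protein for inhibition of 2-Hydroxyacid oxidase 1 (Homo sapiens), with stated times of 30 min and 15 min; on this read-out lower numbers stand for stronger inhibition and higher numbers for weaker inhibition
compound 2 `CC(C)c1csc(-c2cccc(CNc3ccc4[nH]nc(C(=O)O)c4c3)c2O)n1` — 65 nM in this assay

Of the two numbers in hand, compound 2 has the lower; compound 1 sits higher by a gap beyond the usual scatter. Compound 3 `Cc1nc(-c2cccc(CNc3ccc4[nH]nc(C(=O)O)c4c3)c2O)sc1C` differs from compound 2 by 4,5-dimethyl-1,3-thiazol-2-yl in place of 4-isopropyl-1,3-thiazol-2-yl on an aromatic carbon. For the measured compounds named here, no measured pair isolates this exchange, so the expected step is a 1.4-fold higher number from compound 2 to compound 3 (0.14 log units; within the scatter), at most a slight drift toward a higher number and possibly none beyond the scatter. Compound 3 is expected to give 90 nM in this assay, within 35 nM to 230 nM.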

Compound 3, half-maximal inhibitory concentration in the 2-Hydroxyacid oxidase 1 assay: 25 nM
For compound 3 the middle estimate is 3.6-fold (0.56 log units) above the measured one; the measured number lies below the stated range.
By their numbers in the 2-Hydroxyacid oxidase 1 assay, from the lowest: compound 3; then compound 2; then compound 1.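

The thiazole on the aromatic carbon ortho to a hydroxy group is not a neutral place for change: in the 2-Hydroxyacid oxidase 1 assay, 4,5-dimethyl-1,3-thiazol-2-yl in place of 4-isopropyl-1,3-thiazol-2-yl gives a 2.6-fold lower number from compound 2 to compound 3 (0.41 log units; beyond the scatter). In a physicochemical assay for solubility, measured as kinetic solubility, at pH 7.4 (on this read-out higher numbers stand for higher solubility and lower numbers for lower solubility), compound 2 gives 102000 nM and compound 3 gives 15000 nM. The same exchange carries a cost in the physicochemical assay: the measured solubility of compound 2, 102000 nM, and of compound 3, 15000 nM, a 6.8-fold lower number (0.83 log units; beyond the scatter)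

This single pair sets no trend across thiazole substituents. Open, as far as these compounds go, is whether a thiazole bearing an amine or a carboxylic acid would keep the number of compound 3 in the 2-Hydroxyacid oxidase 1 assay without the loss seen in the physicochemical assay.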